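The source may hold more compounds than are shown below. What is called first, only, known or untested is meant among the compounds shown, and "the series" means these compounds.

In a functional assay on MCF7 cells (Homo sapiens) for antiproliferative activity, read by MTT assay, with a stated time of 48 h (on this read-out higher numbers stand for weaker inhibition and lower numbers for stronger inhibition), compound 2 `CC(C)=CCC[C@]1(C)/C=C/[C@@H](OC(=O)C=C(C)C)[C@](C)(O)/C=C/C(=O)/C(CN(C)C)=C\C1` gives 690 nM, the lowest of the two numbers shown; the nearest is compound 1 `C=C1/C=C/C(=O)/C(CO)=C\C[C@](C)(CCC=C(C)C)/C=C/[C@H]1OC(=O)C=C(C)C`, which gives 2750 nM, a gap beyond the scatter. Compound 3 `CC(C)=CCC[C@]1(C)/C=C/[C@@H](OC(=O)C=C(C)C)[C@](C)(O)CCC(=O)/C(CO)=C\C1` gives only a limit, > 40000 nM, corresponding to the limit of > 40000 nM in this assay, at which 1 of the 3 values shown sits. Among the measured compounds shown here, no pair of measured compounds differs in a single place, so no measured step is available to lean on. Compound 4 `CO/N=C/C1=C/C[C@](C)(CCC=C(C)C)/C=C/[C@@H](OC(=O)C=C(C)C)[C@](C)(O)/C=C/C1=O` differs from compound 2 by a group of 4 heavy atoms (2 carbon, 1 nitrogen, 1 oxygen; no ring) in place of a group of 4 heavy atoms (3 carbon, 1 nitrogen; no ring), on a double-bonded ring carbon. For this change a small step towards weaker inhibition in this assay is expected, one that may not clearly exceed the scatter. Compound 4 is accordingly estimated at 1500 nM, within 350 nM to 7000 nM, an expected step of a 2.2-fold higher number from compound 2 to compound 4 (0.34 log units; beyond the scatter).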

Compound 4, half-maximal inhibitory concentration: 2510 nM
Compound 4: middle estimate off by 1.7-fold (0.22 log units), on the low side; the range from low to high includes it.
By their numbers in this assay, from the lowest: compound 2; then compounds 4 and 1 (each within the scatter of the next). At a limit, above all of these: compound 3.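

On this double-bonded ring carbon, the change from (dimethylamino)methyl to the entering group, which holds the same number of heavy atoms, gives in this assay a modest but real loss: a 3.6-fold higher number from compound 2 to compound 4 (0.56 log units; beyond the scatter). The position therefore responds to the group it carries, yet a measured number survives without the dimethylamino group. Nothing measured here accounts for this step.

Open, from the compounds shown here alone, is whether the step follows the loss of the amine or the arrival of the entering group's double bond and oxygen. Also open, going by these compounds, is how a primary amine, a carboxylic acid or a longer chain would read on this carbon.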